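Methoxy in place of methoxycarbonyl: compound 1 to compound 3

This account rests on a few compounds, and the source may have more. Where it says the series, first, only, none or still open, it means among the compounds named here.

Compound 1 `COC(=O)c1ccc(-c2cccc(NC(=O)C(Cl)Cl)c2)cc1` bears the methoxycarbonyl group on an aromatic carbon of a six-membered aromatic ring of carbon only. In a functional assay on A549 cells (Homo sapiens) for cytotoxicity, read by MTT assay, with a stated time of 68 h (a lower number here means a stronger inhibitor, a higher number a weaker inhibitor), compound 1 gives only a limit, > 50000 nM, and no number. That is the situation described by the limit of > 50000 nM in this assay, at which 1 of the 2 values shown sits. The other measured member, compound 2 `O=C(Nc1cccc(-c2ccccc2Cl)c1)C(Cl)Cl`, differs from compound 1 in more than one place; in this assay compound 2 gives 22600 nM. Going by the values given here, no pair of measured compounds differing in a single place is available, so no measured step sets a scale for the series.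

Compound 3 `COc1ccc(-c2cccc(NC(=O)C(Cl)Cl)c2)cc1` is not yet measured. Its change from compound 1 is methoxy in place of methoxycarbonyl on an aromatic carbon. Because compound 1 sits at the limit of > 50000 nM in this assay, at which 1 of the 2 values shown sits, any step in this assay can only appear as a move to a number or as no change. The expected step from compound 1 to compound 3 is an at least 1.2-fold lower number from compound 1 to compound 3 (0.09 log units; that floor lies within the scatter), modest and possibly unresolved. Compound 3 is estimated at 40000 nM in this assay, with an expected range from 15000 nM to 100000 nM.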

Compound 3, half-maximal inhibitory concentration: 8530 nM
Compound 3: middle estimate off by 4.7-fold (0.67 log units), on the high side; measured number outside the range, below it.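

This position, on an aromatic carbon and para to a large group, now proves responsive to substitution. In this assay, going by these compounds alone, methoxy in place of methoxycarbonyl gives an at least 5.8-fold lower number from compound 1 to compound 3 (0.76 log units; beyond the scatter), the only single-place step and so the first measured scale for it. Compound 1 gives > 50000 nM, which is a limit and not a number. The printed size of the step is therefore only a floor, because one end of it rests on a limit: the limit of > 50000 nM in this assay, at which 1 of the 3 values shown sits.

One pair cannot separate the loss of the carbonyl from the smaller heavy-atom count of the entering group, so a hydroxy group, an amine or a carboxylic acid at the same position would be needed to tell which features of the change track with the lower number. Also open, on these data alone, is whether the change keeps its size when the dichloroacetyl group of the shared core gives way to a trifluoroacetyl group.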